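This account rests on a few compounds, and the source may have more. Where it says the series, first, only, none or still open, it means among the compounds named here.

Measured so far in a functional assay on PC-3 cells (Homo sapiens) for cytotoxicity, read by sulforhodamine B assay, with a stated time of 72 h; on this read-out lower numbers stand for stronger inhibition of growth and higher numbers for weaker inhibition of growth: compound 1 `O=C(Nc1ccccc1C(F)(F)F)C1CCc2ccccc2N1C(=O)c1ccccc1` gives 5560 nM. Compound 3 `O=C(Nc1cc(C(F)(F)F)cc(C(F)(F)F)c1)C1CCc2ccccc2N1C(=O)c1cccc(Cl)c1` gives 1050 nM. Compound 2 `CC(=O)N1c2ccccc2CCC1C(=O)Nc1cc(C(F)(F)F)cc(C(F)(F)F)c1` gives > 70000 nM, which is a limit of the assay and not a number.

Among the two numbers, compound 1 stands highest, with compound 3 the nearest and lower by more than the scatter. Compound 4 `O=C(Nc1ccccc1C(F)(F)F)C1CCc2ccccc2N1` differs from compound 1 by hydrogen in place of benzoyl on a nitrogen on an aromatic ring in a ring. Among the compounds with values here, no measured step removes this group outright; the closest is an at least 66-fold lower number from compound 2 to compound 3 (1.82 log units; beyond the scatter), where a small acyl group gave only a limit and a larger aryl acyl gave a much lower number. Taking the group away altogether is therefore expected to raise the number, a step of an 11-fold higher number from compound 1 to compound 4 (1.03 log units; beyond the scatter). For compound 4 the estimate is 60000 nM, between 15000 nM and 200000 nM, and the result may well sit at the limit of > 70000 nM in this assay, at which 1 of the 3 values shown sits.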

Compound 4, concentration for 50% growth inhibition: 53300 nM
For compound 4 the middle estimate is 1.1-fold (0.05 log units) above the measured one; the measured number falls inside the stated range.
By their numbers in this assay, from the lowest: compound 3; then compound 1; then compound 4. At a limit, above all of these: compound 2.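

In this assay, replacing the benzoyl on this nitrogen with hydrogen gives a 9.6-fold higher number from compound 1 to compound 4 (0.98 log units; beyond the scatter), the first step shown that removes the group outright. With hydrogen at this position, compound 4 still gives a measured number, while benzoyl gives the lower number. Compound 2 remains the only compound with a limit and not a number: the limit of > 70000 nM in this assay, at which 1 of the 4 values shown sits.

Going by these compounds, it remains open how a benzoyl carrying an amine or a carboxylic acid would behave at this nitrogen. A longer chain in place of the benzoyl is also an open case.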